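The compounds below may be only part of what the source reports. "The series", "measured", "known", "first", "only" and "open" are said of these compounds alone.

Measured so far:
compound 1, `CCCCc1ccc(C(=O)Nc2cc(C(=O)O)cc(C(=O)O)c2)cc1` — 12.3 mg/kg
compound 2, `O=C(Nc1ccccc1)c1cccc(-c2nn[nH]n2)c1` — 4.5 mg/kg
compound 3, `N#Cc1cccc(C(=O)Nc2cc(C(=O)O)cc(C(=O)O)c2)c1` — 5 mg/kg

In a functional assay on the whole organism with Rattus norvegicus as the target, at a dose of 25 mg/kg by the intravenous route (a higher number here means that more compound is needed for the effect, a lower number that less compound is needed), compound 1 carries the highest of the three numbers; compound 3 and compound 2 both stand below it by margins beyond the usual scatter, so compound 1 is the compound of this set that needs the most material for the effect.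

Compound 4, `O=C(O)c1cc(NC(=O)c2ccc(-c3nn[nH]n3)cc2)cc(C(=O)O)c1`, is not yet measured. It differs from compound 1 in one place: 2H-tetrazol-5-yl in place of butyl on an aromatic carbon. The new group sits on an aromatic carbon of a six-membered aromatic ring of carbon only.

Within the data shown here, no measured pair shows this exact change. Still, compound 2, which also carries 2H-tetrazol-5-yl, gives 4.5 mg/kg, and compound 3 gives 5 mg/kg, both well under compound 1. Compound 4 is therefore expected to move toward a lower number, with an expected step of a 2.5-fold lower number from compound 1 to compound 4 (0.39 log units; beyond the scatter). The estimate for compound 4 is 5 mg/kg, within a range of 2 mg/kg to 12 mg/kg.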

Compound 4, dose for 50% inhibition: 1.2 mg/kg
Compound 4: the middle estimate sits 4.2-fold (0.62 log units) above what was measured; the measured number lies below the stated range.
By their numbers in this assay, from the lowest: compound 4; then compounds 2 and 3 (each within the scatter of the next); then compound 1.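

In this assay, among these compounds, the exchange of butyl for 2H-tetrazol-5-yl on an aromatic carbon, para to a large group, gives a 10-fold lower number from compound 1 to compound 4 (1.01 log units; beyond the scatter) and is the first single-place step in this set. It shows that the number in this assay depends strongly on the group at this position of the core of compound 1. Nothing at hand explains why the step is this large.

The compounds shown leave open whether a carboxylic acid or an amine at this position would give a similar step. They also leave open how a longer chain in place of butyl would compare.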